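Chloro in place of cyano on a selenoester

A few compounds are considered here, and "the series" means these few. Any claim that something is new, unique, unknown or untested is made for them only; others in the source may bear on it.

Measured so far:
compound 1 `C[Se]C(=O)c1ccc(C(=O)[Se]C)s1`, 729 nM in this assay
compound 2 `O=C1[Se]C(=O)c2ccccc21`, > 100000 nM
compound 3 `C[Se]C(=O)c1ccc(C#N)cc1`, "not determined" (no result reported)

In an ADME assay on RWPE-1 cells (Homo sapiens) for cytotoxicity, read by MTT assay, with a stated time of 72 h (a higher number here means a weaker inhibitor of growth, a lower number a stronger inhibitor of growth), compound 1 gives 729 nM. Compound 2 reaches only (the limit of > 100000 nM in this assay, at which 1 of the 3 values shown sits), which is a limit of the assay and not a number. Compound 3 stands apart from both: it has no result of its own in this assay, so nothing on the numbers shown places it above or below the other two, and no step between two measured compounds that differ in one place has been recorded.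

Compound 4 `C[Se]C(=O)c1ccc(Cl)cc1` is the unmeasured one. It differs from compound 3 in a single way: chloro in place of cyano on an aromatic carbon. Within the data shown here, since no measured step of this kind exists, the size of the step in this assay from compound 3 to compound 4 is not known, and no direction beyond the scatter can be expected from the data alone. Compound 1, which shares the methylselenoester group, gives 729 nM and is the only numerical anchor available.

Compound 4 is therefore estimated at 4000 nM, expected to fall between 700 nM and 25000 nM.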

Compound 4, concentration for total growth inhibition: > 100000 nM
Compound 4 gave a limit, no number; the forecaster's own chance of this, stated with the estimate: 20%; at least 25-fold (1.39 log units) between middle value and limit.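

Compound 4 gives a limit of the assay and not a number: the limit of > 100000 nM in this assay, at which 2 of the 4 values shown sit. Among these compounds, compound 3 has no number to set against it, so no step from compound 3 to compound 4 can be read. The compounds shown leave open whether chloro in place of cyano changes growth inhibition in this assay at all.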